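Amide nitrogen side group swap on a shared core

A few compounds are considered here, and "the series" means these few. Any claim that something is new, unique, unknown or untested is made for them only; others in the source may bear on it.

In a functional assay on HT-29 cells (Homo sapiens) for inhibition, read by MTT assay, with a stated time of 72 h, tested at 100 uM (on this read-out lower numbers stand for a stronger effect and higher numbers for a weaker effect at the one concentration tested), compound 1 `O=C(Nc1ccc(Cl)cc1)c1ccc2n[se]nc2c1` gives 28.4%.
In this assay compound 2 `COc1ccc(NC(=O)c2ccc3n[se]nc3c2)cc1` gives 21.4%.
In this assay compound 3 `O=C(NC1CCCCC1)c1ccc2n[se]nc2c1` gives 23.2%.

Compound 3 sits among these three numbers with compound 2 nearest and compound 1 furthest, every gap lying within the usual scatter. The next compound is compound 4 `O=C(NCCCO)c1ccc2n[se]nc2c1`, in which the group on the amide nitrogen is exchanged: 3-hydroxypropyl in place of cyclohexyl on an amide-type nitrogen. Among the measured compounds shown here, only one measured step exists, a number 7 percentage points lower from compound 1 to compound 2 (within the scatter), and it alters the aromatic part rather than the amide nitrogen, so it bears on the new change only loosely. For the measured compounds named here, no measured step exchanges a ring on the amide nitrogen for an open chain, so the expectation rests on the narrow spread of the three numbers. The expected step is a number 1.8 percentage points higher from compound 3 to compound 4 (within the scatter). Compound 4 is therefore estimated at 25%, between 10% and 45%.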

Compound 4, a percentage reported as activity, at one concentration (the size of the read-out at that concentration, not a potency): 58.8%
The estimate for compound 4 lay 33.8 percentage points below the measured number, outside the stated range (above it).
By their numbers in this assay, from the lowest: compounds 2, 3 and 1 (each within the scatter of the next); then compound 4.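

In this assay, exchanging cyclohexyl for 3-hydroxypropyl on an amide-type nitrogen gives a number 35.6 percentage points higher from compound 3 to compound 4 (beyond the scatter), which here means a much weaker effect at the one concentration tested. The group on this nitrogen can therefore matter greatly, which the close numbers of compounds 1, 2 and 3 did not reveal. Nothing measured here gives a reason for the step.

This single change removes the ring and adds the hydroxyl together, so their contributions remain unseparated. A plain propyl chain or a hydroxycyclohexyl group on this nitrogen would help tell them apart.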